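Trimming the ether group: from compound 2 to compound 4

The compounds below may be only part of what the source reports. "The series", "measured", "known", "first", "only" and "open" are said of these compounds alone.

Among the three compounds measured in a functional assay on BGC-823 cells (Homo sapiens) for cytotoxicity, read by MTT assay, with a stated time of 48 h (a lower number here means a stronger inhibitor, a higher number a weaker inhibitor), compound 2 `CN(C)CCCNc1ccnc2cc(OCc3ccc(F)cc3)ccc12` gives the lowest number, 490 nM. Compound 1 `CN(C)CCNc1ccnc2cc(OCc3ccc(F)cc3)ccc12` gives 890 nM, and the step of a 1.8-fold lower number from compound 1 to compound 2 (0.26 log units; within the scatter). Compound 3 `Fc1ccc(COc2ccc3c(Cl)ccnc3c2)cc1` gives 2780 nM, with steps a 3.1-fold higher number from compound 1 to compound 3 (0.49 log units; beyond the scatter) and a 5.7-fold higher number from compound 2 to compound 3 (0.75 log units; beyond the scatter). Compound 4 `CCOc1ccc2c(NCCCN(C)C)ccnc2c1` differs from compound 2 by methyl in place of 4-fluorophenyl on a saturated chain carbon bound to an oxygen on an aromatic ring. Within the data shown here, all three measured steps alter the group carrying the dimethylamino chain; none touches the part that changes in compound 4, so no measured step bears on this change and its size is unknown. Compound 4 is therefore expected, cautiously, to show a 3.1-fold higher number from compound 2 to compound 4 (0.49 log units; beyond the scatter), a modest weakening with a broad range. Compound 4 is estimated at 1500 nM, ranging from 400 nM to 6000 nM.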

Compound 4, half-maximal inhibitory concentration: 9810 nM
Beside the measured number, compound 4's estimate is 6.5-fold (0.82 log units) below it, outside the stated range (above it).
By their numbers in this assay, from the lowest: compounds 2 and 1 (each within the scatter of the next); then compound 3; then compound 4.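

The earlier steps shown here changed only the group carrying the dimethylamino chain, whereas this one changes the ether group: 4-fluorobenzyl to ethyl gives a 20-fold higher number from compound 2 to compound 4 (1.30 log units; beyond the scatter) in this assay. This is the largest step in the set, so the number depends strongly on the ether group. Nothing measured here explains the size of this step. The compounds shown leave open whether the fluorine or the whole aromatic ring matters, which a plain benzyl group would test. A butyl or cyclohexylmethyl group would show how other groups without an aromatic ring behave here.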